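The compounds below may be only part of what the source reports. "The series", "measured", "known", "first", "only" and "open" are said of these compounds alone.

Measured compounds:
compound 1 `Cc1c(C(=O)NCc2cccc(C(F)(F)F)c2)cnn1-c1ccc(Cl)c(Cl)c1` — 500 nM
compound 2 `O=C(NCc1cccc(C(F)(F)F)c1)c1cnn(-c2ccc(Cl)cc2)c1C(F)(F)F` — > 3000 nM
compound 3 `COCc1c(C(=O)NCc2cccc(C(F)(F)F)c2)cnn1-c1ccc(Cl)cc1` — > 3000 nM

Notes on the series. The read-out throughout is a functional assay on cells for antagonist activity at C-C chemokine receptor type 1 (Homo sapiens), read by FLIPR and calcium flux; a higher number here means a weaker inhibitor, a lower number a stronger inhibitor. Among the measured compounds shown here, compound 1 is the only member of the set with a measured number, 500 nM. For compound 2 only a limit of the assay is reported, > 3000 nM. For compound 3 likewise only a limit is reported, > 3000 nM, so compound 3 stands at the edge of what this assay resolves rather than at a number. The step that the two limits leave unreadable from compound 2 to compound 3 is therefore of unreadable size; it connects two limits, as summarised by the limit of > 3000 nM in this assay, at which 2 of the 3 values shown sit.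

Compound 4 `CN(C)c1c(C(=O)NCc2cccc(C(F)(F)F)c2)cnn1-c1ccc(Cl)cc1` has not yet been measured in this assay. Its difference from compound 3 is dimethylamino in place of methoxymethyl on an aromatic carbon, in words: dimethylamino in place of methoxymethyl on an aromatic carbon. For the measured compounds named here, no measured step bears directly on this exchange; the only step in the set, from compound 2 to compound 3, cannot be sized. Two of the three members sit at the limit, so a value around that limit is the working expectation for compound 4, with the number for compound 1 marking how far inside the measurable range a member of this core can reach.

Compound 4 is expected at about 3000 nM, within 800 nM to 10000 nM. This estimate means a step of a number no higher from compound 3 to compound 4 (the limit leaves the size open), which is read as no resolvable change from a limit.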

Compound 4, half-maximal inhibitory concentration: > 3000 nM
Compound 4 gave a limit, no number; the forecaster's own chance of this, stated with the estimate: 60%; the middle value sits exactly at the limit.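

In this assay compound 4 gives > 3000 nM as a limit of the assay, not a number. On these data alone, what remains open is whether dimethylamino, methoxymethyl and trifluoromethyl differ at all on this aromatic carbon. The steps joining compound 2, compound 3 and compound 4 link limits only and cannot be read: the limit of > 3000 nM in this assay, at which 3 of the 4 values shown sit.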